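Diazabicyclic amides at the neuronal acetylcholine receptor

A few compounds are considered here, and "the series" means these few. Any claim that something is new, unique, unknown or untested is made for them only; others in the source may bear on it.

Compound 1 `CCCC(=O)N1CC2CC(C1)N2`: 300 nM
Compound 2 `O=C([C@H]1C[C@H]1F)N1CC2CC(C1)N2`: 62 nM

Within the data shown here, in an assay on CHO cells for agonist activity at Neuronal acetylcholine receptor; alpha3/alpha6/beta2/beta3 (Homo sapiens), read by FLIPR and calcium flux (on this read-out higher numbers stand for an effect only at larger amounts of compound and lower numbers for an effect already at smaller amounts), compound 2 gives 62 nM, the lowest of the two numbers so far, with compound 1 nearest at 300 nM. Compound 3 `C[C@H]1C[C@H]1C(=O)N1CC2CC(C1)N2` carries the change (2-methylcyclopropyl in place of 2-fluorocyclopropyl on a carbonyl carbon). Among the measured compounds shown here, the only measured step, a 4.8-fold lower number from compound 1 to compound 2 (0.68 log units; beyond the scatter), compares a three-membered ring against an open chain, not one ring substituent against another, so it bears on this change only indirectly. A small shift is expected, the estimate for a 1.6-fold higher number from compound 2 to compound 3 (0.21 log units; within the scatter) being within or near the scatter. Compound 3 is therefore estimated at 100 nM, ranging from 30 nM to 300 nM.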

Compound 3, half-maximal effective concentration: 2000 nM
Compound 3: the middle estimate sits 20-fold (1.30 log units) below what was measured; measured number outside the range, above it.
By their numbers in this assay, from the lowest: compound 2; then compound 1; then compound 3.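

Exchanging 2-fluorocyclopropyl for 2-methylcyclopropyl on the carbonyl carbon gives a 32-fold higher number from compound 2 to compound 3 (1.51 log units; beyond the scatter) in this assay, although the heavy-atom count and the three-membered ring stay the same. The three-membered ring alone therefore does not secure a lower number than the open chain: replacing propyl with 2-methylcyclopropyl gives a 6.7-fold higher number from compound 1 to compound 3 (0.82 log units; beyond the scatter), the opposite direction to a 4.8-fold lower number from compound 1 to compound 2 (0.68 log units; beyond the scatter). No evidence on the cause of this gap is available here.
Still open, on these data alone, is where an unsubstituted cyclopropyl, a 2-chlorocyclopropyl or a longer chain would fall on this carbonyl carbon. Also open, as far as these compounds go, is whether the gap holds for the other stereoisomers of these two rings.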